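Methoxy in place of hydrogen on an inactive compound

This account rests on a few compounds, and the source may have more. Where it says the series, first, only, none or still open, it means among the compounds named here.

Compound 1 `COc1ccc(C23OCC24C(CO)C4Cc2cc(OC)c(OC)cc23)cc1OC`: > 100000 nM (limit)
Compound 2 `COc1ccc(C23OCC24C2COC(c5cc(OC)c(OC)cc53)C24)cc1OC`: > 100000 nM (limit)

In a functional assay on SF-539 cells (Homo sapiens) for cytotoxicity (on this read-out higher numbers stand for weaker inhibition of growth and lower numbers for stronger inhibition of growth), compound 2 gives > 100000 nM, which is a limit and not a number. The two measured compounds together show (the limit of > 100000 nM in this assay, at which 2 of the 2 values shown sit). Compound 3 `COc1cc2c(cc1OC)C1(c3cc(OC)c(OC)c(OC)c3)OCC13C1COC2C13` differs from compound 2 by one change: methoxy in place of hydrogen on an aromatic carbon. For the measured compounds named here, no measured step is available to size this change. The expectation rests only on compound 2, whose limit is > 100000 nM. The estimated step of a number no higher from compound 2 to compound 3 (the limit leaves the size open) is expected to stay within the scatter. Compound 3 is expected at 100000 nM, with an estimated range of 30000 nM to 150000 nM.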

Compound 3, concentration for 50% growth inhibition: 31600 nM
For compound 3 the middle estimate is 3.2-fold (0.50 log units) above the measured one, and the stated range covers the measured number.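

Methoxy on this aromatic carbon, ortho to a methoxy group, is the one change shown that brings a compound off the limit, giving an at least 3.1-fold lower number from compound 2 to compound 3 (0.50 log units; beyond the scatter) in this assay. Growth inhibition at this position therefore responds to a group of this kind, though only weakly in absolute terms, as compound 3 gives 31600 nM. Only a minimum for the step can be read: the limit of > 100000 nM in this assay, at which 2 of the 3 values shown sit.

Going by these compounds, whether an amine or a chlorine atom at this aromatic carbon would lower the number further remains open. Also open, on these data alone, is whether methoxy here would act the same way on the core of compound 1.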